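This account rests on a few compounds, and the source may have more. Where it says the series, first, only, none or still open, it means among the compounds named here.

Measured in an ADME assay on the whole organism (strain Wistar Han) for metabolic stability, with Rattus norvegicus as the target, read by LC-MS, at a dose of 0.5 mg/kg by the intravenous route; a higher number here means that the compound lasts longer, a lower number that the compound disappears faster:
Compound 1 `CCS(=O)(=O)c1ccc(OCC[C@@H]2C[C@@H]2C2CCN(c3nc(C(C)C)no3)CC2)c(F)c1` gives 1.8 h
Compound 2 `CC(C)c1noc(N2CCC([C@H]3C[C@H]3COCc3ccc(S(C)(=O)=O)cc3F)CC2)n1` gives 2.2 h
Compound 3 `CCOc1cnc(N2CCC([C@H]3C[C@H]3COCc3ccc(S(C)(=O)=O)c(F)c3)CC2)nc1` gives 0.8 h

In this assay compound 3 stands lowest of the three, and compound 1 and compound 2 both lie above it by more than the scatter. Compound 4 `COCc1cnc(N2CCC([C@H]3C[C@H]3COCc3ccc(S(C)(=O)=O)c(F)c3)CC2)nc1` has not yet been measured. It carries methoxymethyl in place of ethoxy on an aromatic carbon of a six-membered aromatic ring with 2 nitrogen (methoxymethyl in place of ethoxy on an aromatic carbon), with the same atoms joined differently. Within the data shown here, no measured pair differs in one place alone, so the series offers no direct step to go by. Compound 1 and compound 2 also differ from compound 3 in more than this group. The expectation therefore starts from compound 3 at 0.8 h and assumes no shift in either direction beyond the scatter in this assay for this exchange. The expected step is a 1.1-fold higher number from compound 3 to compound 4 (0.05 log units; within the scatter) and would stay within the scatter. For compound 4 the estimated half-life is 0.9 h with an expected range from 0.45 h to 1.8 h in repeated measurements.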

Compound 4, half-life: 1.2 h
Estimate against measurement, compound 4: 1.3-fold (0.12 log units) below, and the stated range covers the measured number.
By their numbers in this assay, from the lowest: compounds 3, 4, 1 and 2 (each within the scatter of the next, the first and the last beyond it).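

In this assay, among these compounds, methoxymethyl in place of ethoxy on an aromatic carbon of the six-membered aromatic ring with 2 nitrogen gives a 1.5-fold higher number from compound 3 to compound 4 (0.18 log units; within the scatter), the first step that can be read at a single place. The two groups have the same atoms joined differently and the same counted hydrogen-bond donors and acceptors, and at this position the exchange leaves the half-life within the scatter. No measurement at hand bears on what lies behind the size of this step.

This single pair leaves open whether the exchange would give a similar step on another core. It also leaves open whether a group of a different kind at this position, such as an amine, a carboxylic acid or a longer chain, would move the half-life beyond the scatter.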